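This account rests on a few compounds, and the source may have more. Where it says the series, first, only, none or still open, it means among the compounds named here.

Three compounds share one core and differ in the group on a saturated chain carbon bound to an amide-type nitrogen. Compound 1 `C=CC1=C(C(=O)NCc2ccc(C)cc2)C(c2ccc(F)cc2)OC1` carries 4-methylbenzyl there. In a functional assay on A549 cells (Homo sapiens) for cytotoxicity, read by MTT assay, with a stated time of 24 h (on this read-out higher numbers stand for weaker inhibition and lower numbers for stronger inhibition), compound 1 reaches only a limit of the assay, > 100000 nM. Compound 2 `C=CC1=C(C(=O)NC(C)(C)C)C(c2ccc(OC)cc2)OC1` differs from compound 1 at more than one place. In this assay compound 2 likewise gives only a limit, > 100000 nM. Going by the values given here, both values sit at the limit of > 100000 nM in this assay, at which 2 of the 2 values shown sit, so compound 1 stands where every measured compound stands, and no step between measured compounds can be stated. Compound 3 `C=CC1=C(C(=O)NCCCCC)C(c2ccc(F)cc2)OC1` has not yet been measured. It differs from compound 1 by butyl in place of 4-methylphenyl on a saturated chain carbon bound to an amide-type nitrogen. With both measured values at the limit, no step beyond the scatter is expected in this assay in either direction. The expected step that the limit leaves unreadable from compound 1 to compound 3 is therefore flat. Compound 3 is estimated to give 150000 nM, within 50000 nM to 500000 nM, most likely again only as a limit.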

Compound 3, half-maximal inhibitory concentration: > 100000 nM
Compound 3: a limit, no number; the forecaster's own chance of this, stated with the estimate: 85%; the middle value is on the limit's open side.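

Going by these compounds alone, compound 3, like compound 1, gives only a limit and not a number, so no step between the two can be read: the limit of > 100000 nM in this assay, at which 3 of the 3 values shown sit. The compounds shown leave open whether any group at this place would give a readable value in this assay.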